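From Hydroxyphenyl Semicarbazide to a Chlorophenyl Urea

The compounds below may be only part of what the source reports. "The series", "measured", "known", "first", "only" and "open" are said of these compounds alone.

Compound 3 `COc1cc(NC(C)CCCNC(=O)NNC(=O)Nc2ccc(O)cc2)c2ncccc2c1` gives 95000 nM in a functional assay on L1210 cells (Mus musculus) for inhibition, read by MTT assay, with a stated time of 72 h (on this read-out lower numbers stand for stronger inhibition and higher numbers for weaker inhibition), which places it second highest of the three numbers measured. Compound 1 `COc1cc(NC(C)CCCNC(=O)NNC(=O)Nc2cccc(F)c2)c2ncccc2c1` gives 108000 nM in this assay; the step of a 1.1-fold lower number from compound 1 to compound 3 (0.06 log units; within the scatter) lies within the scatter. Compound 2 `COc1cc(NC(C)CCCNC(=O)NNC(=O)Nc2cccc(C(F)(F)F)c2)c2ncccc2c1` gives 4000 nM in this assay, and a 24-fold higher number from compound 2 to compound 3 (1.38 log units; beyond the scatter) is large. Compound 4 `COc1cc(NC(C)CCCNC(=O)Nc2cccc(Cl)c2)c2ncccc2c1` differs from compound 3 in one place: 3-chlorophenyl in place of ((4-hydroxyphenyl)carbamoyl)amino on an amide-type nitrogen. Among the measured compounds shown here, no measured step alters this part of the molecule, so only the aryl swaps among compounds 1, 2 and 3 bear on it, and they range from no change to large. Compound 4 is therefore expected to give 30000 nM (range 5000 nM to 150000 nM) in this assay. This estimate means a 3.2-fold lower number from compound 3 to compound 4 (0.50 log units; beyond the scatter), a step expected to be modest and uncertain in direction.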

Compound 4, half-maximal inhibitory concentration: 17000 nM
Estimate against measurement, compound 4: 1.8-fold (0.25 log units) above, and the stated range covers the measured number.
By their numbers in this assay, from the lowest: compound 2; then compound 4; then compounds 3 and 1 (each within the scatter of the next).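

Among the compounds shown here, until now only the aryl group had changed; compound 4 is the first to replace the whole ((4-hydroxyphenyl)carbamoyl)amino group on the amide-type nitrogen. In this assay this brings a 5.6-fold lower number from compound 3 to compound 4 (0.75 log units; beyond the scatter) and, against the 3-fluorophenyl counterpart, a 6.4-fold lower number from compound 1 to compound 4 (0.80 log units; beyond the scatter), so both modest steps run the same way. No data given here account for these steps. On these data alone, it stays open whether the steps belong to the 3-chlorophenyl group itself or to the loss of the carbamoylamino part, and what an amine or a carboxylic acid at this place would give.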